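The source may report more compounds than this note shows. Statements on the series, on what has been measured and on what is new or still open speak of the compounds shown alone.

Compound 1 `O=C(Nc1cccc(-n2cc(-c3ccncc3)c(-c3ccc(Cl)c(O)c3)n2)c1)Nc1cccc(C(F)(F)F)c1` was tested in a functional assay on MDA-MB-435 cells (Homo sapiens) for inhibition, read by sulforhodamine B assay, with a stated time of 48 h (a higher number here means that more compound is tolerated, a lower number that less compound is tolerated), where it gives only a limit of > 32500 nM. Compound 2 `O=C(Nc1cccc(-n2cc(-c3ccncc3)c(-c3ccc(Cl)c(O)c3)n2)c1)Nc1ccc(Cl)c(Cl)c1` differs from it on the amide-type nitrogen, and in this assay compound 2 likewise gives only a limit of > 32500 nM. That leaves a step that the two limits leave unreadable from compound 1 to compound 2. Compound 3 `COc1cc(-c2nn(-c3cccc(NC(=O)Nc4cccc(C(F)(F)F)c4)c3)cc2-c2ccncc2)ccc1Cl` carries a methyl on the aromatic oxygen instead, and in this assay compound 3 gives 8070 nM, which is an at least 4.0-fold lower number from compound 1 to compound 3 (0.60 log units; beyond the scatter). Compound 1 therefore stands at the limit of > 32500 nM in this assay, at which 2 of the 3 values shown sit, and only the change at the oxygen has so far pulled the number into readable territory.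

Compound 4 `O=C(Nc1cccc(-n2cc(-c3ccncc3)c(-c3ccc(Cl)c(O)c3)n2)c1)Nc1cc(C(F)(F)F)cc(C(F)(F)F)c1` changes compound 1 by trifluoromethyl in place of hydrogen on an aromatic carbon, meta to a trifluoromethyl group. The measured step that touches the same nitrogen-bound ring runs from compound 1 to compound 2, and its size cannot be read. The step from compound 1 to compound 3 concerns a different part of the molecule. No basis therefore exists for expecting a move beyond the scatter in this assay in either direction, and compound 4 is expected most likely to sit at the limit again. The estimate for compound 4 is 35000 nM, between 9000 nM and 120000 nM, an expected step that the limit leaves unreadable from compound 1 to compound 4.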

Compound 4, concentration lethal to 50% of the cells: 15600 nM
Beside the measured number, compound 4's estimate is 2.2-fold (0.35 log units) above it; measured number inside the range.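

In this assay, trifluoromethyl in place of hydrogen on this aromatic carbon, meta to a trifluoromethyl group, gives an at least 2.0-fold lower number from compound 1 to compound 4 (0.31 log units; beyond the scatter). Until now, only the methyl on the aromatic oxygen, in compound 3, had brought a readable number, so compound 4 shows that a change on the ring carried by the amide-type nitrogen can do the same while the hydrogen on that oxygen stays in place. Compound 1 has only a limit and no exact value, so this step gives a minimum size and the true difference may be larger: the limit of > 32500 nM in this assay, at which 2 of the 4 values shown sit.

The compounds shown leave open whether this drop belongs to trifluoromethyl in particular or whether another group on the same carbon, such as a nitrile, an amine or a carboxylic acid, would also lower the number. They also leave open whether the second trifluoromethyl and the methyl on the aromatic oxygen would add up in a single molecule, or whether either change would carry over to the 3,4-dichlorophenyl compound 2.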